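Adding a Methoxy Group to the Nitrile Ring of Compound 1

A few compounds are considered here, and "the series" means these few. Any claim that something is new, unique, unknown or untested is made for them only; others in the source may bear on it.

Compound 1 `Cc1ccc2cnc(-c3cccc(C#N)c3)nc2n1` is tested in a functional assay on CHO cells for antagonist activity at metabotropic glutamate receptor 5 (Rattus norvegicus), read by FLIPR and calcium flux (on this read-out lower numbers stand for stronger inhibition and higher numbers for weaker inhibition), where compound 1 gives 240 nM, the higher of the two plain numbers recorded. Compound 3 `Cc1cccc(-c2ncc3ccc(C)nc3n2)c1` gives 53 nM, so that a 4.5-fold lower number from compound 1 to compound 3 (0.66 log units; beyond the scatter). Compound 2 `Cc1ccc2cnc(-c3cccc(CN)c3)nc2n1` reaches only a limit of this assay, > 30000 nM. Compound 4 `COc1cc(C#N)cc(-c2ncc3ccc(C)nc3n2)c1` differs from compound 1 by methoxy in place of hydrogen on an aromatic carbon, on an aromatic carbon of the ring that carries the cyano group. Neither measured step adds a group there: one swaps the cyano itself, giving an at least 120-fold higher number from compound 1 to compound 2 (2.09 log units; beyond the scatter), the other gives a 4.5-fold lower number from compound 1 to compound 3 (0.66 log units; beyond the scatter). Going by the values given here, with no closer precedent, a step within the scatter, or a modest one in either direction, is expected. Compound 4 is therefore estimated at 200 nM, between 60 nM and 800 nM, an expected 1.2-fold lower number from compound 1 to compound 4 (0.08 log units; within the scatter).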

Compound 4, half-maximal inhibitory concentration: 1.2 nM
For compound 4 the middle estimate is 170-fold (2.22 log units) above the measured one, and the stated range ends above it.
By their numbers in this assay, from the lowest: compound 4; then compound 3; then compound 1. At a limit, above all of these: compound 2.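

Methoxy in place of hydrogen, meta to a cyano group, brings a 200-fold lower number from compound 1 to compound 4 (2.30 log units; beyond the scatter) and so shows that this ring carbon, untouched in the earlier compounds, strongly affects the read-out. It also shows that the ring can take an added group while keeping its nitrile. Nothing given here explains why this step is so large.

The compounds shown leave open whether a hydroxyl, an ethoxy or a chlorine on this carbon would do the same. They also leave open whether methoxy would act alike on the ring of compound 3, which has methyl in place of the nitrile.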